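The source may report more compounds than this note shows. Statements on the series, on what has been measured and on what is new or still open speak of the compounds shown alone.

Compounds measured in an assay on cells with melanin-concentrating hormone receptor 1 (Homo sapiens) as the target, read by radioligand binding; a higher number here means a weaker inhibitor, a lower number a stronger inhibitor:
Compound 1, `Nc1ccc2cccc(OCCC(F)(F)F)c2n1`: compound 1 gives 722 nM.
Compound 2, `Nc1ccc2cccc(OCC3CC3)c2n1`: compound 2 reaches only the assay limit of > 2000 nM.

Compound 2 thus has no exact number in this assay; what is known is that it sits at the limit, (the limit of > 2000 nM in this assay, at which 1 of the 2 values shown sits). Among the measured compounds shown here, the one measured step in this set, an at least 2.7-fold higher number from compound 1 to compound 2 (0.44 log units; beyond the scatter), shows that replacing 2,2,2-trifluoroethyl by cyclopropyl on a saturated chain carbon bound to an oxygen on an aromatic ring weakened binding, so the set so far gives no step that raised potency from compound 1.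

Compound 3, `Nc1ccc2cccc(OCC3CCOC3)c2n1`, is the next variation: oxolan-3-yl in place of cyclopropyl on a saturated chain carbon bound to an oxygen on an aromatic ring. For the measured compounds named here, nothing measured here speaks to oxolan-3-yl directly, so the only guide is that compound 2 already lies at the limit. The step from compound 2 to compound 3 is therefore expected to be small, a step that the limit leaves unreadable from compound 2 to compound 3, with a real chance that this assay again returns only a limit. Compound 3 is expected near 3000 nM, in the range 1000 nM to 10000 nM.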

Compound 3, half-maximal inhibitory concentration: 115 nM
Estimate against measurement, compound 3: 26-fold (1.42 log units) above, and the stated range ends above it.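

Groups at this place, on a saturated chain carbon bound to an oxygen on an aromatic ring, can strongly change binding: oxolan-3-yl in place of cyclopropyl gives an at least 17-fold lower number from compound 2 to compound 3 (1.24 log units; beyond the scatter). Oxolan-3-yl in place of 2,2,2-trifluoroethyl gives a 6.3-fold lower number from compound 1 to compound 3 (0.80 log units; beyond the scatter), so compound 3 has the lowest number of the three and is the strongest inhibitor among them. The first of these steps gives only a bound on the size of the change, because compound 2 stands at a limit: the limit of > 2000 nM in this assay, at which 1 of the 3 values shown sits.

The compounds shown do not separate the effect of the ring oxygen from that of the ring size: cyclopentyl, a five-membered ring of carbon only, is not among them. As far as these compounds go, whether the oxygen's place in the ring matters also stays open, and oxolan-2-yl would bear on that question.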